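Exposure of an aryl-for-thiophene swap on a stilbene-type acid

The source may hold more compounds than are shown below. What is called first, only, known or untested is meant among the compounds shown, and "the series" means these compounds.

Measured compounds:
Compound 1, `CC/C(=C(/c1ccc(/C=C/C(=O)O)cc1)c1ccc2[nH]ncc2c1)c1ccccc1`: 5800 ng.h/mL
Compound 2, `CC/C(=C(/c1ccc(/C=C/C(=O)O)cc1)c1ccc2[nH]ncc2c1)c1ccncc1Cl`: 110 ng.h/mL

In an ADME assay on the whole organism for pharmacokinetics, with Mus musculus as the target, at a dose of 10 mg/kg by the oral route (a higher number here means more compound in the circulation at the dose given, a lower number less compound in the circulation), compound 1 gives 5800 ng.h/mL, the highest of the two numbers shown; its nearest neighbour is compound 2, and the step of a 53-fold lower number from compound 1 to compound 2 (1.72 log units; beyond the scatter) is large and beyond the scatter. Compound 3, `CC/C(=C(/c1ccc(/C=C/C(=O)O)cc1)c1ccc2[nH]ncc2c1)c1cscc1C`, is not yet measured in this assay. It differs from compound 1 by 4-methylthiophen-3-yl in place of phenyl on a double-bonded chain carbon bound to a double-bonded chain carbon and a saturated chain carbon. Among the measured compounds shown here, the only measured step at the same place is a 53-fold lower number from compound 1 to compound 2 (1.72 log units; beyond the scatter), where a six-membered ring with one hetero atom and a chlorine replaced phenyl. The change to compound 3 is a different one, a five-membered ring with one hetero atom, so a drop is expected but its size is uncertain. Compound 3 is therefore expected to lie below compound 1 by a 3.9-fold lower number from compound 1 to compound 3 (0.59 log units; beyond the scatter), and its estimated value in this assay is 1500 ng.h/mL, within a range from 300 ng.h/mL to 6000 ng.h/mL.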

Compound 3, area under the concentration-time curve: 3800 ng.h/mL
For compound 3 the middle estimate is 2.5-fold (0.40 log units) below the measured one; low and high end bracket the measured number.
By their numbers in this assay, from the lowest: compound 2; then compounds 3 and 1 (each within the scatter of the next).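

In this assay, a five-membered aromatic ring with a sulfur atom and a methyl group can stand in place of the phenyl of compound 1 with no readable difference, as the step of a 1.5-fold lower number from compound 1 to compound 3 (0.18 log units; within the scatter) lies within the scatter. The large loss seen with 3-chloropyridin-4-yl is therefore not common to every replacement of phenyl at this place, and the step of a 35-fold higher number from compound 2 to compound 3 (1.54 log units; beyond the scatter) sets the two replacements clearly apart. Nothing measured here accounts for that gap.

The compounds shown leave open whether the ring nitrogen or the chlorine of compound 2 goes with its low number, since a pyridine ring without chlorine is not among them. They also leave open whether the methyl group matters for compound 3, which an unsubstituted thiophene ring at this place would test.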